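The source may hold more compounds than are shown below. What is called first, only, known or untested is meant among the compounds shown, and "the series" means these compounds.

Compound 1 `O=S(=O)(NCCCNCc1cccc2ccccc12)c1cc(C(F)(F)F)cc(C(F)(F)F)c1` gives 1400 nM
Compound 2 `O=S(=O)(NCCCNCc1ccc(Cl)cc1)c1cc(C(F)(F)F)cc(C(F)(F)F)c1` gives 2400 nM
Compound 3 `O=S(=O)(NCCNCc1ccc(-c2ccccc2)cc1)c1cc(C(F)(F)F)cc(C(F)(F)F)c1` gives 1400 nM

These three numbers come from a functional assay on MCF7 cells (Homo sapiens) for inhibition, read by MTT assay, with a stated time of 72 h; a lower number here means a stronger inhibitor of growth, a higher number a weaker inhibitor of growth. Compound 2 stands at the highest of the three numbers, yet its gap to compound 1 and its gap to compound 3 each lie within the scatter, so the three compounds cannot be told apart on what has been measured. Among the measured compounds shown here, the single measured step between compounds that differ in one place is a 1.7-fold higher number from compound 1 to compound 2 (0.23 log units; within the scatter), where 4-chlorophenyl takes the place of naphthalen-1-yl on a saturated chain carbon bound to an amine nitrogen, and it stays within the scatter.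

Compound 4 `O=S(=O)(NCCCNCc1ccc(Cl)c(C(F)(F)F)c1)c1cc(C(F)(F)F)cc(C(F)(F)F)c1` has not yet been measured. It differs from compound 2 in one place: trifluoromethyl in place of hydrogen on an aromatic carbon. For the measured compounds named here, no measured step touches a change of this kind; the only step available concerns another part of the molecule and was itself within the scatter. Nothing in the numbers points to a direction, so no step beyond the scatter is expected in this assay. For compound 4 the estimated value in this assay is 1800 nM, within a range from 700 nM to 4500 nM. The step this estimate means is a 1.3-fold lower number from compound 2 to compound 4 (0.12 log units; within the scatter), and it is expected to stay within the scatter.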

Compound 4, concentration for 50% growth inhibition: 3500 nM
The estimate for compound 4 lay 1.9-fold (0.29 log units) below the measured number, and the stated range covers the measured number.
By their numbers in this assay, from the lowest: compounds 1, 3, 2 and 4 (each within the scatter of the next, the first and the last beyond it).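

In this assay, placing trifluoromethyl on the aromatic carbon ortho to the chloro group gives a 1.5-fold higher number from compound 2 to compound 4 (0.16 log units; within the scatter), so this position, which carries only hydrogen in compound 2, accepts a group of four heavy atoms without a step beyond the scatter. The swap of naphthalen-1-yl for 4-chloro-3-(trifluoromethyl)phenyl on the saturated chain carbon gives a 2.5-fold higher number from compound 1 to compound 4 (0.40 log units; beyond the scatter), a modest step and the only one here that lies beyond the scatter, whereas the swap for plain 4-chlorophenyl stayed within it. Nothing available explains these numbers.

The compounds shown leave open whether a different group on the same aromatic carbon, such as fluoro, methoxy or a nitrile, would move the number beyond the scatter from compound 2, and whether trifluoromethyl would give a similar number with hydrogen in place of the chloro group. They also leave open how a longer chain in compound 4 would read in this assay.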